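The source may report more compounds than this note shows. Statements on the series, on what has been measured and on what is new or still open speak of the compounds shown alone.

Compound 1 `CCCCCCCCC#CCOCc1ccc(CCC(=O)O)cc1` gives 100 nM in an assay on isolated protein for inhibition of Arachidonate 12-lipoxygenase (Sus scrofa); a lower number here means a stronger inhibitor, a higher number a weaker inhibitor. Compound 2 `CCCCCCCCCCCCC#CCOCc1ccc(CCC(=O)O)cc1` gives 320 nM. Compound 3 `CCCCCCCCCCCCCCC#CCOCc1ccc(CCC(=O)O)cc1` reaches only the limit of > 10000 nM, which is not a number but the edge of what this assay reports, so compound 3 stands at the limit of > 10000 nM in this assay, at which 1 of the 3 values shown sits. Compound 4 `O=C(O)CCc1ccc(COCC#CCCCCc2ccccc2)cc1` is compound 3 with phenyl in place of decyl on a saturated chain carbon, four bonds along the chain from a triple-bonded carbon. The measured steps that lengthened the chain weakened inhibition, by an at least 100-fold higher number from compound 1 to compound 3 (2.00 log units; beyond the scatter) and an at least 31-fold higher number from compound 2 to compound 3 (1.49 log units; beyond the scatter), so removing most of that chain is expected to reverse this: an expected step of an at least 50-fold lower number from compound 3 to compound 4 (1.69 log units; beyond the scatter), a large move toward stronger inhibition. Compound 4 is therefore estimated at 200 nM, within roughly 50 nM to 1500 nM.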

Compound 4, half-maximal inhibitory concentration: 5000 nM
Estimate against measurement, compound 4: 25-fold (1.40 log units) below, and the stated range ends below it.
By their numbers in this assay, from the lowest: compound 1; then compound 2; then compound 4. At a limit, above all of these: compound 3.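

Until now only alkyl chain length had changed at this position; a ring there gives a clearly weaker inhibitor in this assay than either shorter alkyl chain: a 50-fold higher number from compound 1 to compound 4 (1.70 log units; beyond the scatter) and a 16-fold higher number from compound 2 to compound 4 (1.19 log units; beyond the scatter). Phenyl in place of butyl or octyl therefore does not match them. Compound 3 stands only at a limit, so an at least 2.0-fold lower number from compound 3 to compound 4 (0.30 log units; that floor lies within the scatter) gives a floor and no true size: the limit of > 10000 nM in this assay, at which 1 of the 4 values shown sits.

From the compounds shown here alone, whether the loss belongs to rings in general or to phenyl alone stays open. A cyclohexyl group at this place would separate the two.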